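Benzyl for chloropyridinylmethyl: expectation for compound 3

The source may hold more compounds than are shown below. What is called first, only, known or untested is meant among the compounds shown, and "the series" means these compounds.

Measured so far:
compound 1 `O=C(N/N=C/c1ccccc1O)c1cc(-c2ccc(Cl)cc2)nn1Cc1ccc(Cl)nc1` gives 22500 nM in a functional assay on A549 cells (Homo sapiens) for cytotoxicity, read by MTT assay, with a stated time of 48 h; on this read-out lower numbers stand for lower solubility and higher numbers for higher solubility
compound 2 `COc1ccc(-c2cc(C(=O)N/N=C/c3ccccc3O)n(Cc3ccc(Cl)nc3)n2)cc1` gives 70000 nM in this assay

Among the measured compounds shown here, compound 2 holds the higher of the two numbers; the only measured step is a 3.1-fold higher number from compound 1 to compound 2 (0.49 log units; beyond the scatter), a modest one beyond the scatter. Compound 3 `COc1ccc(-c2cc(C(=O)N/N=C/c3ccccc3O)n(Cc3ccccc3)n2)cc1` differs from compound 2 in one place: phenyl in place of 6-chloropyridin-3-yl on a saturated chain carbon bound to an aromatic nitrogen. For the measured compounds named here, no measured step covers this exchange, and the methoxy-for-chloro step does not bear on it. The expected step in this assay is therefore none beyond the scatter, no change at the digits printed from compound 2 to compound 3 (within the scatter). Compound 3 is estimated at 70000 nM, with a range from 25000 nM to 200000 nM in this assay.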

Compound 3, solubility: 23000 nM
Estimate against measurement, compound 3: 3.0-fold (0.48 log units) above; the measured number lies below the stated range.
By their numbers in this assay, from the lowest: compounds 1 and 3 (each within the scatter of the next); then compound 2.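

At the saturated chain carbon bound to an aromatic nitrogen, phenyl in place of 6-chloropyridin-3-yl gives a 3.0-fold lower number from compound 2 to compound 3 (0.48 log units; beyond the scatter) in this assay. This place therefore moves the read-out, as the aromatic carbon carrying methoxy or chloro does. Nothing available accounts for the step.

The exchange removes the ring nitrogen and the chlorine together, and the compounds shown do not separate the two. Going by these compounds, how an unsubstituted pyridinylmethyl or a chlorobenzyl group would read at this place remains open.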